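Acetamide to methyl carbamate on the shared core

The compounds below may be only part of what the source reports. "The series", "measured", "known", "first", "only" and "open" are said of these compounds alone.

Three compounds share one core and differ in the group on the carbonyl carbon. In an assay on SHEP1 cells for displacement of a labelled ligand from Neuronal acetylcholine receptor; alpha4/beta2 (Homo sapiens), read by scintillation counting, with a stated time of 2 h (a higher number here means a weaker inhibitor, a lower number a stronger inhibitor), compound 1 `C[C@@H]1C[C@@H]1C(=O)N1CC2CNCC2C1` gives 1 nM, compound 2 `C[C@@H]1C[C@H]1C(=O)N1CC2CNCC2C1` gives 4 nM and compound 3 `CC(=O)N1CC2CNCC2C1` gives 38 nM. Compound 3 thus stands highest of the three numbers; the step of a 9.5-fold higher number from compound 2 to compound 3 (0.98 log units; beyond the scatter) and the step of a 38-fold higher number from compound 1 to compound 3 (1.58 log units; beyond the scatter) both exceed the scatter. Between the two cyclopropyl analogues the step of a 4.0-fold higher number from compound 1 to compound 2 (0.60 log units; beyond the scatter) is seen, and the fact that one of compounds 1 and 2 is drawn with a defined configuration and the other without, at the place where they differ is all that distinguishes them.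

Compound 4 `COC(=O)N1CC2CNCC2C1` is not yet measured. It differs from compound 3 as follows: methoxy in place of methyl on a carbonyl carbon. Going by the values given here, no measured step changes the same place in this way. The steps from compound 1 and compound 2 to compound 3 concern a much larger change on the carbonyl carbon and bear on it only as a sign that this position is sensitive. A small step in this assay, in either direction, is expected from compound 3 to compound 4, as a 1.2-fold higher number from compound 3 to compound 4 (0.07 log units; within the scatter). The value expected for compound 4 is 45 nM, within 12 nM to 170 nM.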

Compound 4, inhibition constant: 23 nM
Estimate against measurement, compound 4: 2.0-fold (0.29 log units) above; the measured number falls inside the stated range.
By their numbers in this assay, from the lowest: compound 1; then compound 2; then compounds 4 and 3 (each within the scatter of the next).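

In this assay, methoxy in place of methyl on the carbonyl carbon gives a 1.7-fold lower number from compound 3 to compound 4 (0.22 log units; within the scatter), so the entering oxygen does not separate the two small groups in this measurement. The 2-methylcyclopropyl compounds stand apart from the methoxy compound as they do from the methyl compound, with a 5.8-fold higher number from compound 2 to compound 4 (0.76 log units; beyond the scatter) and a 23-fold higher number from compound 1 to compound 4 (1.36 log units; beyond the scatter), so the sensitivity at this position rests, among these compounds, on the 2-methylcyclopropyl group and not on the exchange of methyl for methoxy. Nothing on hand speaks to a reason for this result.

The compounds shown do not tell how an ethoxy group or an amine on the carbonyl carbon would compare with methoxy and methyl. They also leave open whether a plain cyclopropyl group, without its methyl, would read closer to compound 1 or to compound 3.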